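Ring-opened amine chain replaces methylpiperidinyl ether

A few compounds are considered here, and "the series" means these few. Any claim that something is new, unique, unknown or untested is made for them only; others in the source may bear on it.

Measured compounds:
compound 1 `CC(=O)SCC(=O)c1ccc(NS(=O)(=O)c2ccc(OCc3ccccn3)cc2)nc1`: "not determined" (no result reported)
compound 2 `CC(=O)SCC(=O)c1ccc(NS(=O)(=O)c2ccc(OCCCc3ccccn3)cc2)nc1`: "not determined" (no result reported)
compound 3 `CC(=O)SCC(=O)c1ccc(NS(=O)(=O)c2ccc(OC3CCN(C)CC3)cc2)nc1`: 300 nM

Among the measured compounds shown here, compound 3 is the only member of this small set with a number in a functional assay on U226 cells (Homo sapiens) for cytotoxicity; on this read-out lower numbers stand for an effect already at smaller amounts and higher numbers for an effect only at larger amounts of compound; compound 1 and compound 2 carry no result there, so compound 3 cannot be ranked against anything. Compound 4 `CC(=O)SCC(=O)c1ccc(NS(=O)(=O)c2ccc(OCCCCN(C)C)cc2)nc1` differs from compound 3 by 4-(dimethylamino)butyl in place of 1-methylpiperidin-4-yl on an oxygen on an aromatic ring. For the measured compounds named here, no pair of measured compounds shows what such a change does in this assay. The expected step of a 1.7-fold higher number from compound 3 to compound 4 (0.22 log units; within the scatter) is a small loss, not clearly beyond the scatter. Compound 4 is therefore expected to give 500 nM, within a range from 150 nM to 1500 nM.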

Compound 4, half-maximal effective concentration: 120 nM
Compound 4: the middle estimate sits 4.2-fold (0.62 log units) above what was measured; measured number outside the range, below it.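

In this assay, replacing 1-methylpiperidin-4-yl with 4-(dimethylamino)butyl on the oxygen gives a 2.5-fold lower number from compound 3 to compound 4 (0.40 log units; beyond the scatter). This position therefore keeps its effect without the ring, and the open chain gives the lower number. Nothing available explains this difference.

As far as these compounds go, whether a propyl or pentyl chain ending in the same dimethylamino group would shift the number further remains open. So does the effect of replacing the dimethylamino group with a pyrrolidine, a morpholine or a primary amine at the end of the butyl chain.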